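A few compounds are considered here, and "the series" means these few. Any claim that something is new, unique, unknown or untested is made for them only; others in the source may bear on it.

Measured compounds:
- compound 1 `c1ccc(Cn2cnc3cncnc32)cc1`: 33%
- compound 2 `CN(c1ncnc2c1ncn2Cc1ccccc1)C1CCCC1`: 17%
- compound 3 `c1ccc(Cn2cnc3c(Nc4ccccc4)ncnc32)cc1`: 0%

In a functional assay on the whole organism for inhibition, with Rattus norvegicus as the target, in the maximal electroshock model, at a dose of 25 mg/kg by the intraperitoneal route (a higher number here means more inhibition at the dose given (going by the name of the read-out), a lower number less inhibition), compound 3 gives 0% and stands lowest of the three measured compounds; the nearest is compound 2 and the furthest compound 1, both beyond the scatter. The measured steps all run downward from the unsubstituted compound 1: a number 16 percentage points lower from compound 1 to compound 2 (beyond the scatter) and a number 33 percentage points lower from compound 1 to compound 3 (beyond the scatter), while a number 17 percentage points lower from compound 2 to compound 3 (beyond the scatter) separates the two substituted compounds.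

Compound 4 `CN(C=O)c1ncnc2c1ncn2Cc1ccccc1` is not yet measured. formyl(methyl)amino in place of anilino on an aromatic carbon

Within the data shown here, the step that bears most on this change is the one from compound 2 to compound 3, where an amino group carrying a methyl gave a modest advantage over anilino; compound 4 again carries a methyl on the nitrogen, though with a formyl rather than a cyclopentyl, and with no ring at all. A modest rise from compound 3 is therefore expected, not a return to the level of compound 1, as a step of a number 15 percentage points higher from compound 3 to compound 4 (beyond the scatter). Compound 4 is expected to give 15% in this assay, within 0% to 35%.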

Compound 4, a percentage reported as inhibition, in the whole organism at one dose (the size of the read-out at that dose, not a potency): 0%
Estimate against measurement, compound 4: 15 percentage points above, and the stated range covers the measured number.
By their numbers in this assay, from the lowest: compounds 3 and 4 (each within the scatter of the next); then compound 2; then compound 1.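

In this assay, formyl(methyl)amino, with no ring and no hydrogen-bond donor, reads the same as anilino on this aromatic carbon, with no change at the digits printed from compound 3 to compound 4 (within the scatter). A methyl on the nitrogen does not by itself hold the level of the cyclopentyl(methyl)amino compound: formyl in place of cyclopentyl gives a number 17 percentage points lower from compound 2 to compound 4 (beyond the scatter). All three groups tried on this carbon now fall short of hydrogen, and the formyl(methyl)amino group does so with a number 33 percentage points lower from compound 1 to compound 4 (beyond the scatter).

Nothing at hand explains why these groups differ as they do. Open, as far as these compounds go, is whether a smaller group on this carbon, such as a plain amine, methylamino or methoxy, would stay level with compound 1 at this single dose, or whether any group here lowers the read-out.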